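A few compounds are considered here, and "the series" means these few. Any claim that something is new, unique, unknown or untested is made for them only; others in the source may bear on it.

Measured compounds:
Compound 1 `O=C(CBr)N1N=C(c2ccc(F)cc2)CC1c1ccccc1O` gives 52900 nM
Compound 2 `COc1ccc(C2=NN(C(=O)CN3CCCCC3)C(c3ccccc3O)C2)cc1` gives 59400 nM
Compound 3 `Cc1ccc(C2=NN(C(=O)CN3CCCCC3)C(c3ccccc3O)C2)cc1` gives 45600 nM

All three were tested in an assay on isolated protein for inhibition of Amine oxidase [flavin-containing] B (Homo sapiens), read by fluorescence, with stated times of 15 min and 20 min; on this read-out higher numbers stand for weaker inhibition and lower numbers for stronger inhibition. Compound 3 shows the lowest of the three numbers, but compound 1 and compound 2 both sit within the scatter of it, so the three cannot be ranked against one another. Compound 4 `O=C(CN1CCCCC1)N1N=C(c2ccccc2)CC1c1ccccc1O` differs from compound 3 by a single change: hydrogen in place of methyl on an aromatic carbon.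

Among the compounds with values here, only one measured step bears on this edge of the molecule, and it concerns a different exchange: a 1.3-fold lower number from compound 2 to compound 3 (0.11 log units; within the scatter). Within the data shown here, no measured pair swaps a methyl for a hydrogen at this place, so there is no direct evidence for a shift in either direction, and the one nearby step stayed within the scatter. The expected step is therefore none beyond the scatter. Compound 4 is expected to give 50000 nM in this assay, with a range from 25000 nM to 100000 nM. That expectation amounts to a 1.1-fold higher number from compound 3 to compound 4 (0.04 log units; within the scatter).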

Compound 4, half-maximal inhibitory concentration: 50600 nM
Compound 4: the middle estimate sits 1.0-fold (0.01 log units) below what was measured; the range from low to high includes it.
By their numbers in this assay, from the lowest: compounds 3, 4, 1 and 2 (each within the scatter of the next).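

Compound 4 is the first of these compounds with only a hydrogen at this place on the ring, and taking away the methyl leaves the result unchanged within the scatter: a 1.1-fold higher number from compound 3 to compound 4 (0.05 log units; within the scatter). The same holds when hydrogen replaces methoxy, with a 1.2-fold lower number from compound 2 to compound 4 (0.07 log units; within the scatter), so hydrogen, methyl and methoxy at this position cannot be told apart in this assay, and neither group shows a measurable gain over the plain phenyl. Nothing available explains why these exchanges make so little difference.

These three groups do not settle whether this position is insensitive to every change. A carboxylic acid, an amine or a longer chain at the same place could still move the number in either direction.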